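This account rests on a few compounds, and the source may have more. Where it says the series, first, only, none or still open, it means among the compounds named here.

Of the compounds shown here, three have so far been tested in a functional assay on WM 266-4 cells (Homo sapiens) for inhibition, read by MTT assay, with a stated time of 24 h; a lower number here means a stronger inhibitor of growth, a higher number a weaker inhibitor of growth. Compound 1 `O=C(C1COc2ccccc2O1)N1N=C(c2ccccc2)CC1c1cccc(F)c1` gives 1450 nM. Compound 2 `O=C(c1ccc2c(c1)OCCO2)N1N=C(c2ccccc2)CC1c1ccccc1F` gives 2500 nM, and compound 3 `O=C(c1ccc2c(c1)OCCO2)N1N=C(c2ccccc2)CC1c1ccc(F)cc1` gives 5210 nM. Within the data shown here, compound 3 therefore stands highest of the three numbers; its nearest neighbour is compound 2, and the only measured single change, a 2.1-fold higher number from compound 2 to compound 3 (0.32 log units; beyond the scatter), exchanges a 2-fluorophenyl for a 4-fluorophenyl on the saturated ring carbon. Compound 1, which carries a 3-fluorophenyl on a different core, sits furthest from compound 3.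

Compound 4 `O=C(c1ccc2c(c1)OCCO2)N1N=C(c2ccccc2)CC1c1cccc(F)c1` has not yet been measured. Compared with compound 3 the change is 3-fluorophenyl in place of 4-fluorophenyl on a saturated ring carbon. Among the measured compounds shown here, no measured step covers exactly this exchange, so the expectation rests on two weaker hints: the step of a 2.1-fold higher number from compound 2 to compound 3 (0.32 log units; beyond the scatter) was modest in size, and compound 1, the only compound carrying a 3-fluorophenyl, gives 1450 nM even though its core differs from the shared core of compounds 2, 3 and 4. A modest fall in the number, roughly the size of the measured step, is therefore expected, a 2.1-fold lower number from compound 3 to compound 4 (0.32 log units; beyond the scatter). Compound 4 is estimated at 2500 nM, within a range from 1000 nM to 6000 nM.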

Compound 4, concentration for 50% growth inhibition: 1840 nM
Compound 4: the middle estimate sits 1.4-fold (0.13 log units) above what was measured; measured number inside the range.
By their numbers in this assay, from the lowest: compounds 1, 4 and 2 (each within the scatter of the next); then compound 3.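

In this assay the place of the fluorine on this phenyl ring matters on the shared core: 3-fluorophenyl in place of 4-fluorophenyl on the saturated ring carbon gives (a 2.8-fold lower number from compound 3 to compound 4 (0.45 log units; beyond the scatter)). The 2-fluorophenyl and 3-fluorophenyl compounds cannot be told apart (a 1.4-fold lower number from compound 2 to compound 4 (0.13 log units; within the scatter)), so among these three fluorophenyl isomers only the 4-fluorophenyl of compound 3 stands apart, with a number beyond the scatter of both others. With 3-fluorophenyl held constant, exchanging 2,3-dihydro-1,4-benzodioxin-2-yl for 2,3-dihydro-1,4-benzodioxin-6-yl on the carbonyl carbon leaves the two compounds indistinguishable (a 1.3-fold higher number from compound 1 to compound 4 (0.10 log units; within the scatter)), so this change of core shows no measurable effect on the number here.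

No measurement is available that explains why the 4-fluorophenyl compound differs from the other two isomers. Also open, on these data alone, is how a plain phenyl, a chlorophenyl or a pyridyl ring on this saturated ring carbon would compare with the three fluorophenyl isomers, and whether the same pattern would hold on the core of compound 1.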